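Benzyl in place of butyl on the aromatic nitrogen

A few compounds are considered here, and "the series" means these few. Any claim that something is new, unique, unknown or untested is made for them only; others in the source may bear on it.

Compound 1, `CCCCn1cnc2c(Nc3ccc(Cl)cc3)nc(N[C@H]3CC[C@H](N)CC3)nc21`: 50 nM
Compound 2, `CCCCn1cnc2c(Nc3cccc(Cl)c3)nc(N[C@H]3CC[C@H](N)CC3)nc21`: 160 nM
Compound 3, `CCCCn1cnc2c(Nc3ccccc3)nc(N[C@H]3CC[C@H](N)CC3)nc21`: 20 nM

The three measured compounds share one core and differ only in the aryl group on the amine nitrogen. In a functional assay on EOL1 cells (Homo sapiens) for inhibition, read by fluorescence, with a stated time of 72 h (a lower number here means a stronger inhibitor of growth, a higher number a weaker inhibitor of growth), compound 2 gives the highest number of the three: a 3.2-fold higher number from compound 1 to compound 2 (0.51 log units; beyond the scatter), and an 8.0-fold lower number from compound 2 to compound 3 (0.90 log units; beyond the scatter); between the other two, a 2.5-fold lower number from compound 1 to compound 3 (0.40 log units; beyond the scatter). All three steps are beyond the scatter, yet all three concern the chloro on the aryl ring, not the chain on the aromatic nitrogen.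

Compound 4, `N[C@H]1CC[C@H](Nc2nc(Nc3cccc(Cl)c3)c3ncn(Cc4ccccc4)c3n2)CC1`, keeps the 3-chlorophenyl of compound 2 and changes that chain: phenyl in place of propyl on a saturated chain carbon bound to an aromatic nitrogen. Within the data shown here, no measured step touches this place, so none of the three steps bears directly on the change; the data give no precedent for butyl against benzyl. The expectation therefore rests on compound 2 alone, with 160 nM as the anchor, and it is an expectation of no step beyond the scatter, with a wide range to either side: the step of no change at the digits printed from compound 2 to compound 4 (within the scatter) is expected to be small. Compound 4 is estimated at 160 nM in this assay, between 40 nM and 640 nM.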

Compound 4, concentration for 50% growth inhibition: 380 nM
Beside the measured number, compound 4's estimate is 2.4-fold (0.38 log units) below it, and the stated range covers the measured number.
By their numbers in this assay, from the lowest: compound 3; then compound 1; then compound 2; then compound 4.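

The chain on the aromatic nitrogen is not a silent place in this assay: benzyl in place of butyl gives a 2.4-fold higher number from compound 2 to compound 4 (0.38 log units; beyond the scatter), the first step seen at this position. The step is modest, so an aromatic ring can enter on this saturated chain carbon with only a limited rise in the number, though this rests on a single pair carrying the 3-chlorophenyl group. Nothing at hand accounts for the direction or the size of this step.

The compounds shown leave open whether the same change would give a similar step with the 4-chlorophenyl group of compound 1 or the phenyl group of compound 3. They also leave open how a shorter ethyl chain, a longer hexyl chain or a chain ending in an amine would compare with butyl and benzyl at this place.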